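The compounds below may be only part of what the source reports. "The series", "measured", "known", "first", "only" and "open" are said of these compounds alone.

Measured compounds in an assay on cell membranes for displacement of a labelled ligand from Cholecystokinin receptor type A (Rattus norvegicus), read by CCK-8 assay, with a stated time of 2 h; a lower number here means a stronger inhibitor, a higher number a weaker inhibitor: compound 1 `CN1C(=O)C=C(Cl)C1(O)c1ccccc1` gives 2500 nM; compound 2 `CC(C)N1C(=O)C=C(Cl)C1(O)c1ccccc1` gives 200 nM; compound 3 `CCCCCCN1C(=O)C=C(Cl)C1(O)c1ccccc1` gives 4500 nM.

Compound 3 gives the highest number of the three; compound 1 sits nearest (a 1.8-fold higher number from compound 1 to compound 3 (0.26 log units; within the scatter), within the scatter), compound 2 furthest (a 23-fold higher number from compound 2 to compound 3 (1.35 log units; beyond the scatter)).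

Compound 4 `O=C1C=C(Cl)C(O)(c2ccccc2)N1C1CCCCC1` carries the change (cyclohexyl in place of hexyl on an amide-type nitrogen in a ring). Both large steps bear on it: a 13-fold lower number from compound 1 to compound 2 (1.10 log units; beyond the scatter) and a 23-fold higher number from compound 2 to compound 3 (1.35 log units; beyond the scatter) show that the group on that nitrogen moves this assay strongly, with isopropyl giving the lowest number. The new ring is another six-carbon group without a straight chain, so a step downward well beyond the scatter is expected, though how far is uncertain.

Compound 4 is estimated at 350 nM, range 80 nM to 1600 nM, an expected step of a 13-fold lower number from compound 3 to compound 4 (1.11 log units; beyond the scatter).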

Compound 4, half-maximal inhibitory concentration: > 10000 nM
Compound 4 ended at the assay's limit (the forecaster's own chance of this, stated with the estimate: 5%); middle value at least 28-fold (1.45 log units) away from the limit.
By their numbers in this assay, from the lowest: compound 2; then compounds 1 and 3 (each within the scatter of the next). At a limit, above all of these: compound 4.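

Compound 4 stands at a limit of this assay, not at a number: the limit of > 10000 nM in this assay, at which 1 of the 4 values shown sits. With the carbon count unchanged, cyclohexyl in place of hexyl still gives an at least 2.2-fold higher number from compound 3 to compound 4 (0.34 log units; beyond the scatter), so that count alone does not set the result at this nitrogen. The other two steps, an at least 50-fold higher number from compound 2 to compound 4 (1.69 log units; beyond the scatter) and an at least 4.0-fold higher number from compound 1 to compound 4 (0.60 log units; beyond the scatter), show that a group without a straight chain does not by itself give the low number seen with isopropyl.

Going by these compounds, whether cyclopropyl, cyclobutyl or tert-butyl on that nitrogen would keep the number of compound 2 stays open. On these data alone, the true size of all three steps also stays open.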